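Mirror-Image Pair at the Alpha4/Beta2 Nicotinic Receptor

The source may hold more compounds than are shown below. What is called first, only, known or untested is meant among the compounds shown, and "the series" means these compounds.

Measured compounds:
- compound 1 `CN1CCCN(c2cncc(-c3cc(CCO)no3)c2)CC1`: "not determined" (no result reported)
- compound 2 `COCC[C@@H]1C[C@H]1c1cncc(N2CCCNCC2)c1`: 63%
- compound 3 `COCC[C@@H]1C[C@H]1c1cncc(N2C[C@@H]3C[C@H]2CN3)c1`: "not determined" (no result reported)

In an assay on SH-EP1 cells for agonist activity at Neuronal acetylcholine receptor; alpha4/beta2 (Homo sapiens), read by rubidium efflux, with a stated time of 9.5 min (a lower number here means a smaller maximal response, a higher number a larger maximal response), compound 2 gives 63%. Within the data shown here, this is the only number available; compound 1 and compound 3 have no reported result in this assay, so compound 2 cannot be ranked against anything.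

Compound 4 `COCC[C@H]1C[C@@H]1c1cncc(N2CCCNCC2)c1` has not been measured. Its relation to compound 2 is the two compounds have the same atoms and bonds and differ only in configuration as drawn: 2 of 2 stereo elements differ (all stereocentres are inverted: mirror images); a stereocentre at a saturated ring carbon is drawn S in compound 2 and R in compound 4; a stereocentre at a saturated ring carbon is drawn R in compound 2 and S in compound 4. Among the measured compounds shown here, no pair of measured compounds differing in one place exists here, so the size of such a step is unknown. Mirror images can give the same maximal response or quite different ones, and nothing shown settles which to expect; a modest drop below compound 2, with wide uncertainty, is therefore the estimate.

Compound 4 is expected to give about 50% in this assay, in the range 20% to 85%. The step from compound 2 to compound 4 that this estimate implies, a number 13 percentage points lower from compound 2 to compound 4 (beyond the scatter), is an expectation rather than a measured result.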

Compound 4, largest response reached (reported as efficacy), in percent of the reference or control that the assay uses: 81%
Compound 4: middle estimate off by 31 percentage points, on the low side; the range from low to high includes it.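

In this assay, among these compounds, the earlier compounds offered a single number with nothing to set it against, whereas this pair gives the first measured change, a number 18 percentage points higher from compound 2 to compound 4 (beyond the scatter) and so beyond the usual scatter. The whole step can be traced to the arrangement at the two stereocentres on the saturated ring carbons, because nothing else separates the pair: the fact that compounds 2 and 4 differ only in the configuration as drawn. Handedness at this position therefore changes the maximal response, although the mirror-image change does not abolish it in either compound.

This single pair cannot show whether the same mirror image would again give the larger response with a different amine on the shared core. It also leaves open whether the preference would hold if an ethoxy group or a longer chain replaced the methoxy end of the side chain.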